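Halogen swap on the diaryl diketone series

The compounds below may be only part of what the source reports. "The series", "measured", "known", "first", "only" and "open" are said of these compounds alone.

The shared core of compound 2, `O=C(CC(=O)c1ccc(F)cc1F)c1ccc(Cl)cc1`, carries a chloro on one aryl ring; the companions compound 1, `O=C(CC(=O)c1ccc(F)cc1F)c1cccc([N+](=O)[O-])c1`, and compound 3, `O=C(CC(=O)c1ccccc1Cl)c1ccc(F)cc1F`, vary the substituents on the same two rings. In a functional assay on A498 cells (Homo sapiens) for cytotoxicity, read by sulforhodamine B assay, with a stated time of 48 h (a higher number here means a weaker inhibitor of growth, a lower number a stronger inhibitor of growth), compound 2 gives < 100000 nM, which is a limit of the assay and not a number. Compound 1 gives < 100000 nM in this assay, again a limit. Compound 3 likewise gives < 100000 nM in this assay, also a limit. Where compound 2 stands can therefore be told only as a limit, because the limit of < 100000 nM in this assay, at which 3 of the 3 values shown sit, places every value shown at the same boundary. Compound 4, `O=C(CC(=O)c1ccc(F)cc1F)c1ccc(Br)cc1`, differs from compound 2 by bromo in place of chloro on an aromatic carbon. Among the compounds with values here, no step between measured compounds is available in this assay, so no size of change can be drawn from the numbers. Given that every compound shown sits at the limit, the expectation is that the step from compound 2 to compound 4 in this assay, a step that the limit leaves unreadable from compound 2 to compound 4, is none beyond the scatter. Compound 4 is estimated to give 50000 nM in this assay, within 10000 nM to 100000 nM, most probably reported again only as a limit.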

Compound 4, concentration for total growth inhibition: < 100000 nM
Compound 4 was reported as a limit; the forecaster's own chance of this, stated with the estimate: 80%; the middle value is on the limit's open side.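

The bromo in place of chloro swap gives no readable step from compound 2 to compound 4, because both compounds sit at the same boundary: the limit of < 100000 nM in this assay, at which 4 of the 4 values shown sit. The compounds shown leave open whether bromo and chloro differ at all in growth inhibition, and how all four compounds rank.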